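The source may hold more compounds than are shown below. What is called first, only, known or untested is meant among the compounds shown, and "the series" means these compounds.

Compound 1 `COc1ccc(N(C)c2nc(C)nc3ccccc23)cc1C(=O)OCCC[Se]C#N` is tested in a functional assay on LoVo cells (Homo sapiens) for inhibition, read by MTT assay, with a stated time of 48 h (a higher number here means a weaker inhibitor, a lower number a stronger inhibitor), where compound 1 gives 854 nM. Of the three measured compounds this is the highest number: compound 2 `COc1ccc(N(C)c2nc(C)nc3ccccc23)cc1[Se]C` gives 3 nM, and compound 3 `COc1ccc(N(C)c2nc(C)nc3ccccc23)cc1OCCN` gives 421 nM. Compound 4 `COc1ccc(N(C)c2nc(C)nc3ccccc23)cc1C(=O)OCCCCC[Se]C#N` differs from compound 1 by a group of 5 heavy atoms (3 carbon, 1 nitrogen, 1 selenium; no ring) in place of a group of 3 heavy atoms (1 carbon, 1 nitrogen, 1 selenium; no ring), on a saturated chain carbon, three bonds along the chain from an oxygen next to a carbonyl group. The measured steps are of another kind: both a 280-fold lower number from compound 1 to compound 2 (2.45 log units; beyond the scatter) and a 2.0-fold lower number from compound 1 to compound 3 (0.31 log units; beyond the scatter) exchange the whole group sitting on the aromatic carbon, whereas compound 4 keeps that group and is altered only on a saturated chain carbon within it. Going by the values given here, no measured step therefore speaks directly to this change, and no move beyond the scatter is expected. Compound 4 is expected to give about 850 nM, between 300 nM and 2500 nM. For compound 4 the expected step is thus a 1.0-fold lower number from compound 1 to compound 4 (0.00 log units; within the scatter).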

Compound 4, half-maximal inhibitory concentration: 714 nM
Beside the measured number, compound 4's estimate is 1.2-fold (0.08 log units) above it; measured number inside the range.
By their numbers in this assay, from the lowest: compound 2; then compounds 3, 4 and 1 (each within the scatter of the next, the first and the last beyond it).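

Unlike the earlier steps, which exchange the whole group on the aromatic carbon, this change keeps that group and alters only a saturated chain carbon within it. In this assay it gives a 1.2-fold lower number from compound 1 to compound 4 (0.08 log units; within the scatter), so the group of 5 heavy atoms in place of the group of 3 heavy atoms moves the number by no more than the scatter. Nothing available bears on why this is so. On these data alone, whether a still longer chain also stays within the scatter remains open, and so does the outcome with an amine on this chain.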